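Extending the saturated chain of compound 2

This account rests on a few compounds, and the source may have more. Where it says the series, first, only, none or still open, it means among the compounds named here.

Compound 1 `Cc1cc(O)c(CCC2CCCCC2)c(=O)o1`: 109000 nM
Compound 2 `CCCCCCCCc1c(O)cc(C)oc1=O`: 145000 nM
Compound 3 `CCCCCCc1c(O)cc(C)oc1=O`: > 200000 nM, a limit of the assay

In an ADME assay on L929 cells (Mus musculus, culture collection number NCTC 929) for cytotoxicity, read by MTT assay, with a stated time of 72 h (on this read-out higher numbers stand for weaker inhibition and lower numbers for stronger inhibition), compound 2 gives 145000 nM, which lies within the scatter of compound 1 at 109000 nM. Compound 3 gives > 200000 nM, which is a limit of the assay. Compound 4 `CCCCCCCCCCCCCCCCc1c(O)cc(C)oc1=O` differs from compound 2 as follows: octyl in place of hydrogen on a saturated chain carbon, eight bonds along the chain from an aromatic carbon. Within the data shown here, the one measured step bearing on this change is an at least 1.3-fold higher number from compound 2 to compound 3 (0.13 log units; that floor lies within the scatter). That step shortens the chain, whereas compound 4 carries a longer one, so a modest drop in this assay is expected, with little certainty. The expected step is a 1.5-fold lower number from compound 2 to compound 4 (0.16 log units; within the scatter). For compound 4 the estimated value is 100000 nM, with an expected range of 30000 nM to 200000 nM.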

Compound 4, half-maximal inhibitory concentration: 38200 nM
The estimate for compound 4 lay 2.6-fold (0.42 log units) above the measured number; measured number inside the range.
By their numbers in this assay, from the lowest: compound 4; then compounds 1 and 2 (each within the scatter of the next). At a limit, above all of these: compound 3.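

In this assay, among these compounds, octyl in place of hydrogen on a saturated chain carbon, eight bonds along the chain from an aromatic carbon, gives a 3.8-fold lower number from compound 2 to compound 4 (0.58 log units; beyond the scatter) and is the first change at this position to lie beyond the scatter. Shortening the chain reads differently, with an at least 1.3-fold higher number from compound 2 to compound 3 (0.13 log units; that floor lies within the scatter) as a floor that gives the step no size of its own: the limit of > 200000 nM in this assay, at which 1 of the 4 values shown sits.

From the compounds shown here alone, whether a still longer chain would lower the number further remains open. So does the effect of ending the chain in an amine or a carboxylic acid.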